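A few compounds are considered here, and "the series" means these few. Any claim that something is new, unique, unknown or untested is made for them only; others in the source may bear on it.

In an ADME assay on MT4 cells (Homo sapiens) for cytotoxicity, read by MTT assay, with a stated time of 5 days (a higher number here means that more compound is tolerated, a lower number that less compound is tolerated), compound 1, with structure `C=CC(=O)N1CCC[C@@H](NS(=O)(=O)c2c(C(N)=O)[nH]c3ccc(Br)cc23)C1`, gives 43600 nM, and compound 2, with structure `C=CS(=O)(=O)N1CCC[C@@H](NS(=O)(=O)c2c(C(N)=O)[nH]c3ccc(Br)cc23)C1`, gives 29000 nM. The two differ only by vinylcarbonyl in place of vinylsulfonyl on an amine nitrogen in a ring, and that change made a 1.5-fold higher number from compound 2 to compound 1 (0.18 log units; within the scatter). Compound 3, with structure `C=CS(=O)(=O)N1CC[C@H](NS(=O)(=O)c2c(C(N)=O)[nH]c3ccc(Br)cc23)C1`, gives 16000 nM in this assay; the difference between its core and the core of compound 2 is not broken down here. The values of compound 3 and compound 2 sit close together, while compound 1 shows a clearly higher number than compound 3.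

Compound 4, with structure `C=CC(=O)N1CC[C@H](NS(=O)(=O)c2c(C(N)=O)[nH]c3ccc(Br)cc23)C1`, has not yet been measured. It differs from compound 3 by vinylcarbonyl in place of vinylsulfonyl on an amine nitrogen in a ring. Among the compounds with values here, this is the same kind of change as the one between compound 2 and compound 1, though here the amine nitrogen belongs to a five-membered non-aromatic ring rather than a six-membered one.

Because the earlier change gave a 1.5-fold higher number from compound 2 to compound 1 (0.18 log units; within the scatter), the step from compound 3 to compound 4 is expected to be similarly small, a 1.5-fold higher number from compound 3 to compound 4 (0.18 log units; within the scatter). Compound 4 is therefore estimated to give 24000 nM in this assay, with a likely span from 10000 nM to 55000 nM.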

Compound 4, half-maximal cytotoxic concentration: 155000 nM
Compound 4: the middle estimate sits 6.5-fold (0.81 log units) below what was measured; the whole stated range lies below it.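

In this assay, putting vinylcarbonyl in place of vinylsulfonyl on the ring nitrogen gives a 9.7-fold higher number from compound 3 to compound 4 (0.99 log units; beyond the scatter), and this does not match the same change on the other core: the same change on two cores in this assay, a 1.5-fold higher number (0.18 log units; within the scatter) from compound 2 to compound 1 and a 9.7-fold higher number (0.99 log units; beyond the scatter) from compound 3 to compound 4, 6.4-fold (0.81 log units) apart, beyond the scatter of two such steps.

So in this series, the size of the step depends on the core that carries it, and a step measured on one core cannot simply be carried over to another. Within the data shown here, with only two pairs, this does not show which feature of the cores sets the size of the step, nor how large the step would be on any further core.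

The compounds shown leave open how a propanoyl group, which has no vinyl double bond, would compare with vinylcarbonyl and vinylsulfonyl on the ring nitrogen of either core. They also leave open whether the two steps would still differ with chlorine in place of the bromine.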